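Cyanoguanidine thioether series: aminopyrimidine variant on the chain

The source may hold more compounds than are shown below. What is called first, only, known or untested is meant among the compounds shown, and "the series" means these compounds.

Measured so far in a functional assay on Sf9 cells for antagonist activity at histamine H2 receptor (Homo sapiens), read by scintillation counting and GTPgammaS binding, with a stated time of 90 min; on this read-out lower numbers stand for lower potency and higher numbers for higher potency (the scale is a negative logarithm):
compound 1 `N#C/N=C(/NCCCCNc1nc(N)n[nH]1)NCCSc1ccccc1` gives < 5
compound 2 `N#C/N=C(/NCCCNc1ccccn1)NCCSc1ccccc1` gives < 5
compound 3 `N#C/N=C(/NCCCCNc1ccccn1)NCCSc1ccccc1` gives < 5

Every value above is a limit of this assay, not a number. Compound 3 stands at that limit, as do the other two, which is summed up by the limit of < 5 in this assay, at which 3 of the 3 values shown sit. The step that the two limits leave unreadable from compound 1 to compound 2 cannot be read for size, nor can a step that the two limits leave unreadable from compound 1 to compound 3 or a step that the two limits leave unreadable from compound 2 to compound 3; none of them says anything about direction or scatter.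

Compound 4 `N#C/N=C(/NCCCNc1nccc(N)n1)NCCSc1ccccc1` is not yet measured. The change is (4-aminopyrimidin-2-yl)amino in place of ((pyridin-2-yl)amino)methyl on a saturated chain carbon, three bonds along the chain from an amine nitrogen. For the measured compounds named here, no measured step bears on it in a readable way: the three compounds give only the same limit, so the series offers no slope to extrapolate from. The step from compound 3 to compound 4 is therefore expected to be a number no lower from compound 3 to compound 4 (the limit leaves the size open), an expectation resting on nothing more than the shared limit. Compound 4 is expected at 5, with a range from 4 to 6, and a substantial chance that this assay again reports only a limit.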

Compound 4, negative logarithm of the antagonist equilibrium constant: < 5
Compound 4: a limit, no number; the forecaster's own chance of this, stated with the estimate: 60%; the middle value lies on the limit itself.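

For the compounds shown here, compound 4 also returns only a limit in this assay, so no step linking it to compound 1, compound 2 or compound 3 can be read: the limit of < 5 in this assay, at which 4 of the 4 values shown sit. The compounds shown leave open whether any of these changes shifts potency, and in which direction.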